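A dimethylamino group added to compound 3

The source may report more compounds than this note shows. Statements on the series, on what has been measured and on what is new or still open speak of the compounds shown alone.

Compound 1 `COc1cc(/C=C/C(=O)C2=C(/C=C/c3ccc(O)c(OC)c3)NC(=O)NC2c2ccccc2)ccc1O` gives 25000 nM
Compound 2 `COc1cc(/C=C/C(=O)C2=C(/C=C/c3ccc(O)c(OC)c3)NC(=O)NC2c2ccccc2O)ccc1O` gives 100000 nM
Compound 3 `COc1cc(/C=C/C(=O)C2=C(/C=C/c3ccc(O)c(OC)c3)NC(=S)NC2c2ccccc2)ccc1O` gives 100000 nM
Compound 4 `COc1cc(/C=C/C(=O)C2=C(/C=C/c3ccc(O)c(OC)c3)NC(=S)NC2c2ccc(N(C)C)cc2)ccc1O` has not yet been measured

In a functional assay on HCT-116 cells (Homo sapiens) for cytotoxicity, read by MTT assay, with a stated time of 48 h (a lower number here means a stronger inhibitor, a higher number a weaker inhibitor), compound 3 shares the highest number of the three with compound 2, and only compound 1 lies lower. Compound 4 carries dimethylamino in place of hydrogen on an aromatic carbon and is otherwise unchanged. Within the data shown here, one measured step bears on this, and only loosely: hydroxy in place of hydrogen gave a 4.0-fold higher number from compound 1 to compound 2 (0.60 log units; beyond the scatter) on a different parent with a different group. With compound 3 already at 100000 nM the likeliest outcome is no step beyond the scatter, and any real move is expected to be downward. The expected result is a 1.7-fold lower number from compound 3 to compound 4 (0.22 log units; within the scatter) in this estimate. For compound 4 the estimated value is 60000 nM (expected range 20000 nM to 130000 nM).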

Compound 4, half-maximal inhibitory concentration: 12500 nM
Compound 4: the middle estimate sits 4.8-fold (0.68 log units) above what was measured; measured number below the stated range.
By their numbers in this assay, from the lowest: compounds 4 and 1 (each within the scatter of the next); then compounds 2 and 3 (each within the scatter of the next).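

In this assay, dimethylamino on the aromatic carbon para to a large group gives an 8.0-fold lower number from compound 3 to compound 4 (0.90 log units; beyond the scatter), so adding a group at this place on the ring can lower the number. The earlier step on this ring, a 4.0-fold higher number from compound 1 to compound 2 (0.60 log units; beyond the scatter), ran the other way, with hydroxy on a different parent, so what is added to the ring can shift the number in either direction. Nothing measured here explains the drop. From the compounds shown here alone, whether a plain amino group or a methoxy group at this place would lower the number as well remains open. So does whether dimethylamino would do the same on the parent of compound 1.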